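The source may report more compounds than this note shows. Statements on the series, on what has been measured and on what is new or still open speak of the compounds shown alone.

In a functional assay on MT4 cells (Homo sapiens) for cytotoxicity, read by MTT assay (on this read-out lower numbers stand for higher toxicity in this test and higher numbers for lower toxicity in this test), compound 3 `CNNC(=O)c1[nH]c2ccc(Cl)cc2c1S(=O)(=O)c1cc(C)cc(C)c1` gives > 100 uM. That reading is a limit and not a number: it is the limit of > 100 uM in this assay, at which 1 of the 3 values shown sits. Two relatives with the same core give real numbers, with compound 1 `Cc1cc(C)cc(S(=O)(=O)c2c(C(=O)NCC(N)=O)[nH]c3ccc(Cl)cc23)c1` at 45 uM and compound 2 `Cc1cc(C)cc(S(=O)(=O)c2c(C(=O)NN3CCOC3=O)[nH]c3ccc(Cl)cc23)c1` at 100 uM.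

The next compound, compound 4 `Cc1cc(C)cc(S(=O)(=O)c2c(C(=O)NNC(C)C)[nH]c3ccc(Cl)cc23)c1`, changes only the end of the side chain: isopropyl in place of methyl on an amine nitrogen. In words, isopropyl stands in place of methyl on an amine nitrogen.

Within the data shown here, no measured step makes this exact swap. The nearest evidence comes from changes on the amide-type nitrogen that carries this chain. There, an at least 2.2-fold higher number from compound 1 to compound 3 (0.34 log units; beyond the scatter) and a 2.2-fold higher number from compound 1 to compound 2 (0.35 log units; beyond the scatter) are both modest, though only just beyond the scatter, while a number no lower from compound 2 to compound 3 (the limit leaves the size open) leaves the size open. Changes to this side chain have therefore moved this assay only modestly so far, so a large step is not expected here. A small move toward a lower number, meaning somewhat higher toxicity, is the expected direction, and it may not rise beyond the scatter.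

The expected change is an at least 1.2-fold lower number from compound 3 to compound 4 (0.09 log units; that floor lies within the scatter). For compound 4 the estimate is 80 uM, with an expected range from 30 uM to 150 uM.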

Compound 4, half-maximal toxic concentration: > 100 uM
Compound 4 was reported as a limit (the forecaster's own chance of this, stated with the estimate: 50%); middle value at least 1.2-fold (0.09 log units) away from the limit.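

In this assay compound 4 reads as a limit and not a number, and so does compound 3. The step between these two compounds therefore cannot be read, and the swap of methyl for isopropyl on the amine nitrogen has no measurable effect to report. Putting isopropylamino in place of 2-oxo-1,3-oxazolidin-3-yl on the amide-type nitrogen gives a number no lower from compound 2 to compound 4 (the limit leaves the size open). The one comparison readable in size replaces carbamoylmethyl with isopropylamino on the amide-type nitrogen and gives an at least 2.2-fold higher number from compound 1 to compound 4 (0.34 log units; beyond the scatter), which shows that the isopropyl end, like the methyl end before it, stays clearly apart from compound 1, and both ends of this chain now stop at the same limit: the limit of > 100 uM in this assay, at which 2 of the 4 values shown sit.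

From the compounds shown here alone, whether compound 3 and compound 4 differ at all in this assay remains open, since neither has a real number to compare. Also open, going by these compounds, is whether a longer chain such as n-butyl, a cyclohexyl ring, or a chain ending in a carboxylic acid on this amine nitrogen would give a real number, and on which side of the value of compound 1 it would fall.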